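The compounds below may be only part of what the source reports. "The series", "measured", "known", "first", "only" and "open" are said of these compounds alone.

Measured so far:
- compound 1, `Cc1cc(OCc2ccccc2)c2nc(C)c(C)n2c1`: 86%
- compound 2, `Cc1nc2c(OCc3ccccc3)cccn2c1N`: 99%

In a functional assay on the whole organism with Rattus norvegicus as the target, at a dose of 40 mg/kg by the intraperitoneal route (a higher number here means more inhibition at the dose given (going by the name of the read-out), a lower number less inhibition), compound 2 gives 99%, the highest of the two numbers in hand. Its nearest neighbour is compound 1, which in this assay gives 86%; that gap lies beyond the usual scatter. Going by the values given here, the two compounds differ in more than one place, so the pair carries no single step to lean on.

Compound 3, `Cc1cc(OCc2ccccc2)c2nc(C)c(N)n2c1`, is not yet measured. It differs from compound 2 by methyl in place of hydrogen on an aromatic carbon. Among the compounds with values here, no measured pair shows this change, so the expectation rests on compound 2 alone, whose number in this assay already stands high. A small change of this kind is expected to leave the read-out where it is: the step of a number 4 percentage points lower from compound 2 to compound 3 (within the scatter) is estimated to fall within the scatter, with no direction beyond it. Compound 3 is therefore expected to give 95% in this assay, with a range from 80% to 100%.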

Compound 3, a percentage reported as inhibition, in the whole organism at one dose (the size of the read-out at that dose, not a potency): 65%
Compound 3: the middle estimate sits 30 percentage points above what was measured; measured number below the stated range.
By their numbers in this assay, from the lowest: compound 3; then compound 1; then compound 2.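

In this assay, the aromatic carbon two atoms from the ring nitrogen proves sensitive to substitution: methyl in place of hydrogen there gives a number 34 percentage points lower from compound 2 to compound 3 (beyond the scatter) and so moves the read-out well beyond what a one-carbon change had suggested. With that methyl present, amino in place of methyl on the other aromatic carbon gives a number 21 percentage points lower from compound 1 to compound 3 (beyond the scatter) and thus lowers the read-out on this background, a step the earlier pair could not isolate. Nothing at hand bears on the reason for either step.

On these data alone, whether ethyl, methoxy or chlorine at the same carbon would follow methyl stays open. Also open, as far as these compounds go, is whether amino in place of methyl lowers the read-out when hydrogen, not methyl, occupies that carbon.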